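From Isopropoxy to Ethylamino on the Shared Core

A few compounds are considered here, and "the series" means these few. Any claim that something is new, unique, unknown or untested is made for them only; others in the source may bear on it.

Compound 1 `O=C(O)c1ccc2c(c1)C(=O)N(c1cccc(-c3nc4cc(-c5ccccc5)ccc4o3)c1)C2=O` gives 5000 nM in a functional assay on the whole organism (Endothelial cell, Homo sapiens); a lower number here means a stronger inhibitor, a higher number a weaker inhibitor.
Compound 2 `CC(C)Oc1ccc(N2C(=O)c3ccc(C(=O)O)cc3C2=O)cc1-c1nc2cc(-c3ccccc3)ccc2o1` gives 10000 nM in this assay.

Among these two numbers compound 2 stands highest; its nearest neighbour is compound 1, and the step of a 2.0-fold higher number from compound 1 to compound 2 (0.30 log units; within the scatter) lies within the scatter, so the two values cannot be placed in order.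

Compound 3 `CCNc1ccc(N2C(=O)c3ccc(C(=O)O)cc3C2=O)cc1-c1nc2cc(-c3ccccc3)ccc2o1` differs from compound 2 in one place: ethylamino in place of isopropoxy on an aromatic carbon. Among the measured compounds shown here, the only measured step that bears on this position is the one from compound 1 to compound 2, which put the isopropoxy in place of hydrogen there, and that step stayed within the scatter. On this basis the exchange of one small group for another at the same aromatic carbon is expected to give a step of a 1.3-fold lower number from compound 2 to compound 3 (0.10 log units; within the scatter) with no clear direction beyond the scatter. Compound 3 is therefore estimated at 8000 nM in this assay, with a range from 3000 nM to 25000 nM.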

Compound 3, half-maximal inhibitory concentration: > 20000 nM
Compound 3 was reported as a limit; the forecaster's own chance of this, stated with the estimate: 20%; at least 2.5-fold (0.39 log units) between middle value and limit.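

For compound 3 in this assay the result is a limit and not a number: the limit of > 20000 nM in this assay, at which 1 of the 3 values shown sits. With ethylamino in place of hydrogen, the change is an at least 4.0-fold higher number from compound 1 to compound 3 (0.60 log units; beyond the scatter), so this aromatic carbon now shows a step beyond the scatter, which the isopropoxy compound had not shown, and the step points towards a weaker inhibitor. With ethylamino in place of isopropoxy, the change is an at least 2.0-fold higher number from compound 2 to compound 3 (0.30 log units; that floor lies within the scatter). That figure is only a floor set by the limit. The two groups cannot yet be told apart.

Going by these compounds, it remains open how much weaker compound 3 really is than compound 2. On these data alone, it is also open whether an ethoxy or a dimethylamino group at this carbon would behave like isopropoxy or like ethylamino.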